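The source may report more compounds than this note shows. Statements on the series, on what has been measured and on what is new or still open speak of the compounds shown alone.

Of the compounds shown here, three have so far been read in a functional assay on cells (Homo sapiens) for cytotoxicity, read by MTT assay, with a stated time of 72 h; on this read-out lower numbers stand for stronger inhibition and higher numbers for weaker inhibition. Compound 1 (`COc1ccc(-c2nc3ccccc3n2C(=O)c2cccc3ccccc23)cc1`) gives > 10000 nM, which is a limit of the assay. Compound 2 (`COc1ccc(C(=O)n2c(CC(C)C)nc3ccccc32)cc1`) gives > 10000 nM, again a limit. Compound 3 (`COc1ccc(C(=O)n2c(C(C)C)nc3ccccc32)cc1`) gives > 10000 nM, also a limit, so no number places it. The picture so far is uniform: the limit of > 10000 nM in this assay, at which 3 of the 3 values shown sit.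

Compound 4 (`COc1ccc(C(=O)n2c(C3CCCCC3)nc3ccccc32)cc1`) has cyclohexyl in place of isopropyl on an aromatic carbon. Among the measured compounds shown here, the one measured step that bears on this change is a swap of groups on the same carbon, a step that the two limits leave unreadable from compound 2 to compound 3. Its size cannot be read, so it offers no magnitude or direction to carry over, and no step beyond the scatter is expected in this assay. The expected step, with its direction left open by the data, is a step that the limit leaves unreadable from compound 3 to compound 4. For compound 4 the estimated value is 12000 nM, with an expected range from 4000 nM to 30000 nM, and the assay may well report only a limit again.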

Compound 4, half-maximal inhibitory concentration: > 10000 nM
Compound 4 gave a limit, no number; the forecaster's own chance of this, stated with the estimate: 75%; the middle value does not contradict the limit.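

Compound 4 also gives only a limit, so the steps linking it to compound 2 and compound 3 cannot be read. The compounds shown leave open whether any group at this place changes the read-out, since all share one reading: the limit of > 10000 nM in this assay, at which 4 of the 4 values shown sit.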